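A few compounds are considered here, and "the series" means these few. Any claim that something is new, unique, unknown or untested is made for them only; others in the source may bear on it.

Among the compounds with values here, in a functional assay on BT-474 cells (Homo sapiens) for inhibition, read by MTT assay, with a stated time of 5 days (on this read-out lower numbers stand for stronger inhibition and higher numbers for weaker inhibition), the series so far is flat. Compound 1 `Cc1cc(Nc2nc(NCc3ccccc3F)nc3[nH]ncc23)n[nH]1` gives 13200 nM, compound 2 `Cc1cc(Nc2nc(NCc3cccc(Cl)c3)nc3[nH]ncc23)n[nH]1` gives 12900 nM and compound 3 `Cc1cc(Nc2nc(NCc3ccc(Cl)cc3)nc3[nH]ncc23)n[nH]1` gives 11700 nM. Compound 3 therefore stands level with the other two within the scatter. The steps that reach it are a 1.1-fold lower number from compound 1 to compound 3 (0.05 log units; within the scatter) and a 1.1-fold lower number from compound 2 to compound 3 (0.04 log units; within the scatter).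

Compound 4 `Cc1cc(Nc2nc(NCc3ccc(Br)cc3)nc3[nH]ncc23)n[nH]1` carries one change from compound 3: bromo in place of chloro on an aromatic carbon. This is bromo in place of chloro on an aromatic carbon, para to a large group. Within the data shown here, no measured step makes this exchange. The closest evidence is the set of phenyl exchanges above, together with a 1.0-fold lower number from compound 1 to compound 2 (0.01 log units; within the scatter), and all of them lie within the scatter. No step beyond the scatter is therefore expected in this assay, in either direction. The expected change is a 1.0-fold lower number from compound 3 to compound 4 (0.01 log units; within the scatter). Compound 4 is estimated at 11500 nM, with an expected range of 6500 nM to 20000 nM.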

Compound 4, half-maximal inhibitory concentration: 4110 nM
Beside the measured number, compound 4's estimate is 2.8-fold (0.45 log units) above it; measured number below the stated range.
By their numbers in this assay, from the lowest: compound 4; then compounds 3, 2 and 1 (each within the scatter of the next).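

In this assay, within the data shown here, the halogen on the aromatic carbon para to a large group does affect the read-out: bromo in place of chloro gives a 2.8-fold lower number from compound 3 to compound 4 (0.45 log units; beyond the scatter) and is the first step beyond the scatter. The wider exchanges that reach the 4-bromophenyl group agree, with a 3.1-fold lower number from compound 2 to compound 4 (0.50 log units; beyond the scatter) and a 3.2-fold lower number from compound 1 to compound 4 (0.51 log units; beyond the scatter), whereas the steps among compound 1, compound 2 and compound 3 all lay within the scatter and gave no sign of this difference. No measurement at hand accounts for the difference between chloro and bromo at this position.

From the compounds shown here alone, whether iodo, methyl or trifluoromethyl at this position would extend the step remains open. Also open, going by these compounds, is whether bromo elsewhere on the ring would give a step of similar size.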